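Ester and acid on two cores: one step measured, one expected

The source may report more compounds than this note shows. Statements on the series, on what has been measured and on what is new or still open speak of the compounds shown alone.

The measured compounds:
compound 1 `CCOC(=O)/C=C/c1ccc(OCc2nc(C)c(C)nc2C)cc1` gives > 2000000 nM
compound 2 `CCOC(=O)/C=C/c1cc(OC)c(OCc2nc(C)c(C)nc2C)c(OC)c1` gives 631000 nM
compound 3 `Cc1nc(C)c(COc2ccc(/C=C/C(=O)O)cc2)nc1C` gives 1400000 nM

The three compounds were tested in a functional assay on a cell-free system (Platelet, plasma, Oryctolagus cuniculus) for inhibition, with a stated time of 5 min; a lower number here means a stronger inhibitor, a higher number a weaker inhibitor. Compound 1 reaches only the limit of the assay, > 2000000 nM, and no number is reported for it; this is the limit of > 2000000 nM in this assay, at which 1 of the 3 values shown sits. Compound 3 differs from compound 1 by hydrogen in place of ethyl on an oxygen next to a carbonyl group, and the step is an at least 1.4-fold lower number from compound 1 to compound 3 (0.15 log units; that floor lies within the scatter). Compound 2 carries a different core from compound 1, and the difference between the two cores is not broken down here. In this assay compound 2 gives 631000 nM, the lowest of the two numbers reported, and its nearest neighbour is compound 3.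

Compound 4 `COc1cc(/C=C/C(=O)O)cc(OC)c1OCc1nc(C)c(C)nc1C` has not been measured. It differs from compound 2 by hydrogen in place of ethyl on an oxygen next to a carbonyl group, the same change that turns compound 1 into compound 3. Since the step from compound 1 to compound 3 is an at least 1.4-fold lower number from compound 1 to compound 3 (0.15 log units; that floor lies within the scatter), a step of similar size or a little larger, towards a lower number, is expected from compound 2 to compound 4, namely a 1.6-fold lower number from compound 2 to compound 4 (0.20 log units; within the scatter). Among the compounds with values here, that expectation rests only on the one measured step, whose floor lies within the scatter, so the range is kept wide. For compound 4 the estimate is 400000 nM, between 150000 nM and 1200000 nM.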

Compound 4, half-maximal inhibitory concentration: 182000 nM
Compound 4: the middle estimate sits 2.2-fold (0.34 log units) above what was measured; the range from low to high includes it.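

In this assay, putting hydrogen in place of ethyl on an oxygen next to a carbonyl group, on the second core, gives a 3.5-fold lower number from compound 2 to compound 4 (0.54 log units; beyond the scatter). Both steps of this change run towards a lower number, so the direction holds on the two cores shown, but that is only two cores, and the data do not show whether the size of the step carries over from one to the other: the same change on two cores in this assay, an at least 1.4-fold lower number (0.15 log units; that floor lies within the scatter) from compound 1 to compound 3 and a 3.5-fold lower number (0.54 log units; beyond the scatter) from compound 2 to compound 4; the limit leaves it open whether they differ The first step has no firm size, since compound 1 gives a limit rather than a number: the limit of > 2000000 nM in this assay, at which 1 of the 4 values shown sits.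

The compounds shown leave open whether the lower number belongs to the free carboxy group as such or would also appear with other replacements for the ethoxycarbonyl group, such as a primary amide, a methyl ester or a tetrazole. They also leave open what would happen to this step on a core carrying other substituents, such as a fluorine or a hydroxy group, and whether a saturated chain in place of the 2-carboxyethenyl group would give a step of the same direction.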